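This account rests on a few compounds, and the source may have more. Where it says the series, first, only, none or still open, it means among the compounds named here.

Measured compounds:
compound 1 `CCc1cc(C(C)=O)c(O)cc1OCCCCCCCC(C)(C)C#N` gives 29%
compound 2 `CCc1cc(C(C)=O)c(O)cc1OCCCCCCC(C)(C)c1nnn[nH]1` gives 67%
compound 3 `CCc1cc(C(C)=O)c(O)cc1OCCCCCC(C)(C)c1nnnn1C` gives 59%

In an assay on isolated protein for binding affinity to leukotriene B4 receptor 1 (Homo sapiens), tested at 1 uM (a lower number here means less inhibition, a higher number more inhibition at the concentration tested (going by the name of the read-out)), compound 3 stands second highest of the three numbers. Its nearest neighbour is compound 2, and the step of a number 8 percentage points lower from compound 2 to compound 3 (within the scatter) lies within the scatter; its furthest is compound 1, from which the step of a number 30 percentage points higher from compound 1 to compound 3 (beyond the scatter) is a modest rise. For the measured compounds named here, the one large step among the three, a number 38 percentage points higher from compound 1 to compound 2 (beyond the scatter), replaces a nitrile-bearing group with a tetrazole.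

Compound 4 `CCc1cc(C(C)=O)c(O)cc1OCCCCCC(C)(C)c1nnn(C)n1` is built from the same atoms as compound 3, joined differently: 2-methyl-2H-tetrazol-5-yl in place of 1-methyl-1H-tetrazol-5-yl on a saturated chain carbon bound to three saturated chain carbons. Going by the values given here, no measured step moves a methyl from one tetrazole ring nitrogen to another. Among the compounds with values here, the only step that touches the tetrazole substitution at all is the exchange from compound 2 to compound 3, which stayed within the scatter, so the account expects the step of a number 1 percentage points lower from compound 3 to compound 4 (within the scatter) to show no movement beyond the scatter, in either direction. Compound 4 is therefore estimated at 58%, with a range from 40% to 74%.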

Compound 4, a percentage reported as inhibition, at one concentration (the size of the read-out at that concentration, not a potency): 66%
Compound 4: the middle estimate sits 8 percentage points below what was measured; measured number inside the range.
By their numbers in this assay, from the lowest: compound 1; then compounds 3, 4 and 2 (each within the scatter of the next).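

In this assay the shift of the methyl to give 2-methyl-2H-tetrazol-5-yl in place of 1-methyl-1H-tetrazol-5-yl produces a number 7 percentage points higher from compound 3 to compound 4 (within the scatter) and so this read-out does not separate the two ring isomers at this chain carbon. The new isomer also matches the tetrazole that carries no methyl, with a number 1 percentage points lower from compound 2 to compound 4 (within the scatter) as the step, yet it stands clear of the nitrile, with a number 37 percentage points higher from compound 1 to compound 4 (beyond the scatter) as the step, so all three tetrazoles now sit apart from the nitrile whichever ring nitrogen bears the methyl, if any does. Nothing available explains why the place of the methyl matters so little here.

The compounds shown leave open whether a tetrazole is needed at all, since a carboxylic acid or an amide on the same carbon could answer that. They also leave open how 2-methyl-2H-tetrazol-5-yl behaves on a longer chain.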